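The source may hold more compounds than are shown below. What is called first, only, known or untested is meant among the compounds shown, and "the series" means these compounds.

Measured compounds:
- compound 1, `ClCc1ccc(Cn2cnc3c(Cl)ncnc32)cc1`: > 100000 nM
- compound 2, `ClCc1cccc(Cn2cnc3ncnc(Cl)c32)c1`: 22400 nM
- compound 3, `ClCc1ccc(Cn2cnc3nc(Cl)nc(Cl)c32)cc1`: 31600 nM

In a functional assay on CCRF-CEM cells (Homo sapiens) for cytotoxicity, read by sulforhodamine B assay, with a stated time of 48 h (a lower number here means a stronger inhibitor of growth, a higher number a weaker inhibitor of growth), compound 2 gives 22400 nM. Compound 3 gives 31600 nM in this assay, and the two numbers sit within the usual scatter of each other, so no order between compound 2 and compound 3 can be read from them. Compound 1 gives only a limit, > 100000 nM, in this assay. Thus compound 2 stands alongside compound 3 among the numbers, with compound 1 set apart as the one value that is a limit (the limit of > 100000 nM in this assay, at which 1 of the 3 values shown sits).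

Compound 4, `ClCc1cccc(Cn2cnc3nc(Cl)nc(Cl)c32)c1`, has not been measured in this assay. It differs from compound 2 by chloro in place of hydrogen on an aromatic carbon. Among the measured compounds shown here, no measured pair tracks this change directly. The closest reading available is the pair compound 1 and compound 3, where compound 1 sits at a limit and compound 3 gives a number; what that pair shows is a gain, but it cannot be sized. For compound 4 the expected step from compound 2 is a 1.0-fold lower number from compound 2 to compound 4 (0.01 log units; within the scatter), and the estimate for compound 4 in this assay is 22000 nM, within 7000 nM to 70000 nM.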

Compound 4, concentration for total growth inhibition: 2750 nM
The estimate for compound 4 lay 8.0-fold (0.90 log units) above the measured number, and the stated range ends above it.
By their numbers in this assay, from the lowest: compound 4; then compounds 2 and 3 (each within the scatter of the next). At a limit, above all of these: compound 1.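

Among the compounds shown here, this is the first direct reading of the change: in this assay, chloro in place of hydrogen on the aromatic carbon between two ring nitrogen atoms gives an 8.1-fold lower number from compound 2 to compound 4 (0.91 log units; beyond the scatter) with the rest of the structure unchanged. The earlier compounds shown here offered no pair differing in this one place, so they could not show that this carbon tolerates a chloro group and that growth inhibition gains from it. The reading rests on a single pair, and nothing at hand gives a cause for the step.

Open, going by these compounds, is whether the gain is specific to chloro or extends to other groups on this carbon, such as fluoro, methoxy or an amine. Also open, on these data alone, is whether the same change gives a similar step with the chloromethyl group placed as in compound 3.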